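Chalcone-pyrazole series: dichlorophenyl in place of aminophenyl

The compounds below may be only part of what the source reports. "The series", "measured", "known", "first", "only" and "open" are said of these compounds alone.

Compound 1 `COc1ccc(-c2cc(/C=C/C(=O)c3ccc(N)cc3)[nH]n2)cc1` and compound 2 `COc1cc(-c2cc(/C=C/C(=O)c3ccc(N)cc3)[nH]n2)cc(OC)c1OC` share the same core and differ in the methoxy pattern on the aryl ring attached to it. In a functional assay on Hs-578T cells (Homo sapiens) for inhibition, read by sulforhodamine B assay, with a stated time of 48 h (on this read-out higher numbers stand for weaker inhibition of growth and lower numbers for stronger inhibition of growth), compound 1 gives 4040 nM, and in this assay compound 2 gives 4330 nM. For the measured compounds named here, compound 2 therefore stands at the highest of the two numbers known so far, but the two values lie within the scatter of each other, so nothing can be said about an order between them.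

Compound 3 `COc1cc(-c2cc(/C=C/C(=O)c3ccc(Cl)c(Cl)c3)[nH]n2)cc(OC)c1OC` keeps the core and the trimethoxy aryl ring of compound 2 and differs only at the carbonyl end: 3,4-dichlorophenyl in place of 4-aminophenyl on a carbonyl carbon. Going by the values given here, no measured pair covers this kind of exchange, so the size of the step is not anchored by data. A modest step is expected, more likely toward a somewhat lower number than a higher one, but a result within the scatter cannot be ruled out.

Compound 3 is estimated at 3200 nM in this assay, with a range from 800 nM to 13000 nM. The step this estimate means is a 1.4-fold lower number from compound 2 to compound 3 (0.13 log units; within the scatter).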

Compound 3, concentration for 50% growth inhibition: 16600 nM
For compound 3 the middle estimate is 5.2-fold (0.71 log units) below the measured one; the whole stated range lies below it.
By their numbers in this assay, from the lowest: compounds 1 and 2 (each within the scatter of the next); then compound 3.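

For the compounds shown here, the earlier pair varied only the methoxy pattern on the aryl ring and gave no order, whereas this is the first change at the aryl group on a carbonyl carbon. In this assay, 3,4-dichlorophenyl in place of 4-aminophenyl gives a 3.8-fold higher number from compound 2 to compound 3 (0.58 log units; beyond the scatter), which shows that this position responds to the exchange and that, with the trimethoxy aryl ring held fixed, the dichlorophenyl compound inhibits growth more weakly. The exchange replaces a group counted with a hydrogen-bond donor and acceptor by one counted with neither, but no measurement bearing on the reason for the step is available.

A single exchange at this position cannot separate the effect of adding the two chlorine atoms from that of removing the amine, a question that an unsubstituted phenyl, a monochlorophenyl or a hydroxyphenyl at the same carbonyl carbon would address. As far as these compounds go, it also remains open whether a step of this size would recur with the methoxy pattern of compound 1 on the aryl ring.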